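Closing a gem-dimethyl into a cyclohexane ring

The source may hold more compounds than are shown below. What is called first, only, known or untested is meant among the compounds shown, and "the series" means these compounds.

Measured compounds:
compound 1 `CCC(CC)(CC(=O)Nc1cccc(OCc2ccc3ccc(Br)cc3n2)c1)C(=O)O` – 4 nM
compound 2 `CC(C)(CC(=O)Nc1cccc(OCc2ccc3ccc(F)cc3n2)c1)C(=O)O` – 1.4 nM

In a functional assay on ileum (Cavia porcellus) for antagonist activity at cysteinyl leukotriene receptor (Homo sapiens) (a higher number here means a weaker inhibitor, a lower number a stronger inhibitor), compound 2 gives 1.4 nM, the lowest of the two numbers shown. For the measured compounds named here, its nearest neighbour is compound 1, which gives 4 nM, a higher number by a gap that lies beyond the usual scatter; the two structures differ in more than one place, so no single step is drawn between them.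

Compound 3 `O=C(CC1(C(=O)O)CCCCC1)Nc1cccc(OCc2ccc3ccc(F)cc3n2)c1` is not yet measured. It differs from compound 2 by 1-carboxycyclohexyl in place of 1-carboxy-1-methylethyl on a saturated chain carbon bound to a carbonyl carbon. Going by the values given here, with no measured step of this kind to lean on, the expected change in this assay is modest and of uncertain direction, and may well stay within the scatter.

Compound 3 is therefore expected to fall near 2.2 nM, within 0.6 nM to 8 nM, which corresponds to an estimated step of a 1.6-fold higher number from compound 2 to compound 3 (0.20 log units; within the scatter).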

Compound 3, half-maximal inhibitory concentration: 7.3 nM
Beside the measured number, compound 3's estimate is 3.3-fold (0.52 log units) below it; the measured number falls inside the stated range.
By their numbers in this assay, from the lowest: compound 2; then compounds 1 and 3 (each within the scatter of the next).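

In this assay, for the compounds shown here, the change from 1-carboxy-1-methylethyl to 1-carboxycyclohexyl, on a saturated chain carbon bound to a carbonyl carbon, gives a 5.2-fold higher number from compound 2 to compound 3 (0.72 log units; beyond the scatter) and is the first single-place step at this position. It shows that this position is not indifferent to the group it carries: closing the two methyl groups into a six-membered carbon ring moves the number in the weaker direction, beyond the scatter. Nothing available explains this loss.

A single ring size cannot show whether the loss tracks ring size, so a 1-carboxycyclopropyl or 1-carboxycyclopentyl group at this position remains an open case. Compound 1 differs from compound 2 in more than one place, so it cannot show whether the same step would hold with bromine on the core in place of fluorine.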